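A Larger Amide Substituent and Expected Antiproliferative Potency

A few compounds are considered here, and "the series" means these few. Any claim that something is new, unique, unknown or untested is made for them only; others in the source may bear on it.

Three compounds sharing one core, compound 1 `CCC(=O)Nc1cccc(S(=O)(=O)Oc2ccccc2C(C)C)c1`, compound 2 `CC(=O)Nc1ccc(S(=O)(=O)Oc2ccccc2C(C)C)cc1` and compound 3 `CCNC(=O)Nc1ccc(S(=O)(=O)Oc2ccccc2I)cc1`, have been tested in a functional assay on MCF7 cells (Homo sapiens) for antiproliferative activity, read by sulforhodamine B assay, with a stated time of 48 h; on this read-out lower numbers stand for stronger inhibition and higher numbers for weaker inhibition. Compound 1 gives 14000 nM, compound 2 gives 16000 nM, and compound 3 gives 1100 nM. Compound 2 thus shows the highest of the three numbers; compound 1 sits within the usual scatter of it, while compound 3 sits far beyond it. The new compound 4, `CC(C)c1ccccc1OS(=O)(=O)c1ccc(NC(=O)NC2CCCC2)cc1`, differs from compound 2 in a single place: cyclopentylamino in place of methyl on a carbonyl carbon. For the measured compounds named here, no measured pair isolates exactly this change, and compound 3 differs from compound 4 in more than one place, so it is only a loose guide. The change is nevertheless expected to give a step of a 4.6-fold lower number from compound 2 to compound 4 (0.66 log units; beyond the scatter) toward a lower number. Compound 4 is therefore estimated at 3500 nM, within a range from 900 nM to 14000 nM.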

Compound 4, half-maximal inhibitory concentration: 6200 nM
Estimate against measurement, compound 4: 1.8-fold (0.25 log units) below; low and high end bracket the measured number.
By their numbers in this assay, from the lowest: compound 3; then compound 4; then compounds 1 and 2 (each within the scatter of the next).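

For the compounds shown here, putting cyclopentylamino in place of methyl on this carbonyl carbon gives a 2.6-fold lower number from compound 2 to compound 4 (0.41 log units; beyond the scatter) in this assay, the only comparison here that changes a single place. The position therefore accepts a much larger group, one with a five-membered ring and a hydrogen-bond donor, without a rise in the number, although the step is modest. Nothing available explains this step. As far as these compounds go, whether the ring or the added nitrogen matters more stays open. A cyclopentyl group attached directly to the carbonyl carbon, or a small methylamino group there, would help separate the two.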